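The source may report more compounds than this note shows. Statements on the series, on what has been measured and on what is new or still open speak of the compounds shown alone.

Three compounds in this series have been examined in an ADME assay on RD cells (Homo sapiens) for cytotoxicity, read by MTT assay, with a stated time of 24 h; a higher number here means that more compound is tolerated, a lower number that less compound is tolerated. Compound 1 `CCO/N=C/c1cc(C)c(OCCC(C)CCN2CCN(c3ccnc(N)c3)C2=O)c(C)c1` gives 12900 nM in this assay. Compound 2 `CC(CCOc1ccc(-c2noc(C(F)(F)F)n2)cc1)CCN1CCN(c2ccnc(N)c2)C1=O` gives 48100 nM in this assay, the higher of the two numbers, with compound 1 lying lower by a gap that is beyond the usual scatter. Compound 3 `CCO/N=C/c1ccc(OCCC(C)CCN2CCN(c3ccnc(OC)c3)C2=O)cc1` reaches only the limit of this assay, > 100000 nM, and no number is known for it; this is the limit described as the limit of > 100000 nM in this assay, at which 1 of the 3 values shown sits.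

Compound 4 `Cc1nc(-c2ccc(OCCC(C)CCN3CCN(c4ccnc(N)c4)C3=O)cc2)no1` has not yet been measured. It differs from compound 2 in one place: methyl in place of trifluoromethyl on an aromatic carbon. Within the data shown here, no measured pair in this set shares that change, so no step size can be read from the data. The step from compound 2 to compound 4 in this assay is expected to be small, a 1.2-fold higher number from compound 2 to compound 4 (0.10 log units; within the scatter), with no direction firmly beyond the scatter, and a somewhat higher number is thought slightly more likely. Compound 4 is therefore estimated at 60000 nM, within a range of 25000 nM to 150000 nM.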

Compound 4, half-maximal cytotoxic concentration: 66100 nM
Compound 4: the middle estimate sits 1.1-fold (0.04 log units) below what was measured; the measured number falls inside the stated range.
By their numbers in this assay, from the lowest: compound 1; then compounds 2 and 4 (each within the scatter of the next). At a limit, above all of these: compound 3.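

In this assay the exchange of trifluoromethyl for methyl on the aromatic carbon next to the ring nitrogen and next to the ring oxygen gives a 1.4-fold higher number from compound 2 to compound 4 (0.14 log units; within the scatter) and so leaves compound 2 and compound 4 indistinguishable. Among these compounds, this is the first step that can be read at a single place, and it shows that going from 4 heavy atoms to 1 heavy atom here does not move the number beyond the scatter. Nothing measured among these compounds speaks to the cause of this step.

On these data alone, whether an ethyl group, an amine or a carboxylic acid on this same carbon would also stay within the scatter of compound 2 remains open. As far as these compounds go, it is equally open whether the 5-methyl-1,2,4-oxadiazol-3-yl group would behave the same way on the core of compound 1.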